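Swapping the para substituent: iodo to methyl

The source may hold more compounds than are shown below. What is called first, only, known or untested is meant among the compounds shown, and "the series" means these compounds.

Compound 1, `COc1ccc(/N=C2\C=C(OCc3cn(S(=O)(=O)c4ccc(C)cc4)nn3)C(=O)c3ccccc32)cc1`: 8390 nM
Compound 2, `Cc1ccc(S(=O)(=O)n2cc(COC3=C/C(=N\c4ccc(I)cc4)c4ccccc4C3=O)nn2)cc1`: > 16300 nM

In a functional assay on NCI-H460 cells (Homo sapiens) for cytotoxicity, read by MTT assay, with a stated time of 72 h (a lower number here means a stronger inhibitor, a higher number a weaker inhibitor), compound 1 gives 8390 nM. Compound 2 reaches only the limit of this assay, > 16300 nM, so for it the measurements give a floor and no number; this is recorded as the limit of > 16300 nM in this assay, at which 1 of the 2 values shown sits. For the measured compounds named here, the one measured step, an at least 1.9-fold higher number from compound 1 to compound 2 (0.28 log units; that floor lies within the scatter), is iodo in place of methoxy on an aromatic carbon.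

Compound 3, `Cc1ccc(/N=C2\C=C(OCc3cn(S(=O)(=O)c4ccc(C)cc4)nn3)C(=O)c3ccccc32)cc1`, is not yet measured in this assay. It differs from compound 2 by methyl in place of iodo on an aromatic carbon. Going by the values given here, no measured pair shows methyl against iodo at this place, and the only nearby step, an at least 1.9-fold higher number from compound 1 to compound 2 (0.28 log units; that floor lies within the scatter), ends at a limit, so the size of the change from compound 2 is uncertain. A modest move back toward the number of compound 1, or none beyond the scatter, is expected, an at least 1.3-fold lower number from compound 2 to compound 3 (0.13 log units; that floor lies within the scatter). For compound 3 an estimate of 12000 nM is expected, within the range 5000 nM to 30000 nM.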

Compound 3, half-maximal inhibitory concentration: 8020 nM
For compound 3 the middle estimate is 1.5-fold (0.18 log units) above the measured one, within the range that was stated.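

For the compounds shown here, this result gives the first pair at this position where both compounds carry a real number. In this assay the step is a 1.0-fold lower number from compound 1 to compound 3 (0.02 log units; within the scatter), so methyl and methoxy on this aromatic carbon cannot be told apart. Against iodo the step is an at least 2.0-fold lower number from compound 2 to compound 3 (0.30 log units; that floor lies within the scatter), which is only a floor and does not go beyond the scatter, and compound 2 itself is held at a limit and not a number: the limit of > 16300 nM in this assay, at which 1 of the 3 values shown sits.

How far the iodo compound truly lies from the other two therefore stays open, and so far no change at this place has a step shown beyond the scatter. The compounds shown also leave open how an amine, a carboxylic acid or a longer chain in this place would compare with methyl and methoxy.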